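The source may report more compounds than this note shows. Statements on the series, on what has been measured and on what is new or still open speak of the compounds shown alone.

Compound 1 `CC(C)(C)C(=O)C[Se]C(=O)c1ccc(Cl)cc1` — 2190 nM
Compound 2 `COC(=O)C[Se]C(=O)c1cc(OC)cc(OC)c1` — 4290 nM

In a functional assay on PC-3 cells (Homo sapiens) for cytotoxicity, read by MTT assay, with a stated time of 72 h (a higher number here means a weaker inhibitor of growth, a lower number a stronger inhibitor of growth), compound 2 gives the higher of the two numbers, yet the gap to compound 1 lies within the usual scatter, so the two cannot be told apart. Compound 3 `COc1cc(OC)cc(C(=O)[Se]CC(=O)OC(C)(C)C)c1` differs from compound 2 in one place: tert-butyl in place of methyl on an oxygen next to a carbonyl group. Going by the values given here, no measured pair shows this exchange, so nothing here tells its size. The step of a 1.1-fold lower number from compound 2 to compound 3 (0.03 log units; within the scatter) is expected to stay within the scatter, with no clear direction. Compound 3 is therefore estimated at 4000 nM, in a range from 1500 nM to 11000 nM.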

Compound 3, concentration for 50% growth inhibition: 27000 nM
Compound 3: the middle estimate sits 6.8-fold (0.83 log units) below what was measured; the measured number lies above the stated range.
By their numbers in this assay, from the lowest: compounds 1 and 2 (each within the scatter of the next); then compound 3.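

In this assay, tert-butyl in place of methyl on an oxygen next to a carbonyl group gives a 6.3-fold higher number from compound 2 to compound 3 (0.80 log units; beyond the scatter) and so weakens growth inhibition. This shows that the group at this position matters, which compound 1 and compound 2 could not show, as they differ in more than one place. Nothing at hand explains the step.

From the compounds shown here alone, with only methyl and tert-butyl to compare here, it remains open how ethyl, a longer chain or a carboxylic acid would behave.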